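A few compounds are considered here, and "the series" means these few. Any claim that something is new, unique, unknown or untested is made for them only; others in the source may bear on it.

Measured in a functional assay on PC-3 cells (Homo sapiens) for inhibition, read by MTT assay, with a stated time of 48 h, tested at 10 uM; a lower number here means less inhibition of growth, a higher number more inhibition of growth at the concentration tested:
- compound 1 `CN1CC[C@H](c2c(O)cc(O)c3c(=O)cc(/C=C/c4ccccc4)oc23)[C@H](O)C1`: 10%
- compound 2 `CN1CC[C@H](c2c(O)cc(O)c3c(=O)cc(/C=C/c4cccc(Cl)c4)oc23)[C@H](O)C1`: 53%
- compound 3 `CN1CC[C@H](c2c(O)cc(O)c3c(=O)cc(/C=C/c4ccccc4F)oc23)[C@H](O)C1`: 25%

Of these three, compound 3 stands in the middle, with 25%. The next structure is compound 4 `CN1CC[C@H](c2c(O)cc(O)c3c(=O)cc(/C=C/c4ccccc4Cl)oc23)[C@H](O)C1`, which differs from it as follows: chloro in place of fluoro on an aromatic carbon. This puts chloro in place of fluoro on an aromatic carbon, ortho to a large group.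

Among the compounds with values here, two measured steps bear on this change. Fluoro in place of hydrogen gave a number 15 percentage points higher from compound 1 to compound 3 (beyond the scatter), while chloro in place of hydrogen gave the larger a number 43 percentage points higher from compound 1 to compound 2 (beyond the scatter). However, that chloro belongs to a 3-chlorophenyl, not a 2-chlorophenyl, so only part of that gain is expected to carry over.

A modest rise is therefore expected in this assay, an estimated a number 13 percentage points higher from compound 3 to compound 4 (beyond the scatter). For compound 4 the estimated value is 38%, with an expected range of 22% to 56%.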

Compound 4, percent growth inhibition at one concentration: 22%
Estimate against measurement, compound 4: 16 percentage points above, within the range that was stated.
By their numbers in this assay, from the lowest: compound 1; then compounds 4 and 3 (each within the scatter of the next); then compound 2.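

In this assay, chloro in place of fluoro on this aromatic carbon gives a number 3 percentage points lower from compound 3 to compound 4 (within the scatter), so the two halogens cannot be told apart at this position. Moving the chloro has a far greater effect: 2-chlorophenyl in place of 3-chlorophenyl gives a number 31 percentage points lower from compound 2 to compound 4 (beyond the scatter), while chloro in place of hydrogen at this position gives only a number 12 percentage points higher from compound 1 to compound 4 (beyond the scatter). Nothing available explains why the location of the chloro matters so much.

On these data alone, it remains open whether a 3-fluorophenyl would match the 3-chlorophenyl of compound 2, and how a methoxy group or an amine would behave on the same ring.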